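Replacing Methoxy with tert-Butyl on the Aryl Ring

A few compounds are considered here, and "the series" means these few. Any claim that something is new, unique, unknown or untested is made for them only; others in the source may bear on it.

Compound 1, `COc1ccc(N2C(=O)NC3(CSC4=C3C(=O)c3ncccc3C4=O)C2=O)cc1`, was tested in a functional assay on ACHN cells (Homo sapiens) for antiproliferative activity, read by MTT assay, with a stated time of 96 h (on this read-out lower numbers stand for stronger inhibition and higher numbers for weaker inhibition), where compound 1 gives 50 nM. Of the three measured compounds, compound 1 sits level with compound 3, the two together holding the highest numbers. Compound 3, `CCCCc1ccc(N2C(=O)NC3(CSC4=C3C(=O)c3ncccc3C4=O)C2=O)cc1`, gives 50 nM in this assay. Compound 2, `Cc1ccc(N2C(=O)NC3(CSC4=C3C(=O)c3ncccc3C4=O)C2=O)cc1`, gives 12 nM in this assay and is the one that stands apart.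

The steps among these three are the only guide. There is a 4.2-fold lower number from compound 1 to compound 2 (0.62 log units; beyond the scatter), there is no change at the digits printed from compound 1 to compound 3 (within the scatter), and there is a 4.2-fold higher number from compound 2 to compound 3 (0.62 log units; beyond the scatter).

Compound 4, `CC(C)(C)c1ccc(N2C(=O)NC3(CSC4=C3C(=O)c3ncccc3C4=O)C2=O)cc1`, differs from compound 1 in one place: tert-butyl in place of methoxy on an aromatic carbon. Both earlier exchanges of the methoxy for an alkyl group gave either a modest fall or no change, and the four-carbon tert-butyl matches the butyl in heavy atoms. A step no larger than within the scatter, or a slight fall, is therefore expected. Compound 4 is expected to give 30 nM, with a range from 10 nM to 90 nM. The expected step is a 1.7-fold lower number from compound 1 to compound 4 (0.22 log units; within the scatter).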

Compound 4, half-maximal inhibitory concentration: 150 nM
Estimate against measurement, compound 4: 5.0-fold (0.70 log units) below, outside the stated range (above it).
By their numbers in this assay, from the lowest: compound 2; then compounds 1 and 3 (each within the scatter of the next); then compound 4.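

The result shows that an alkyl group on this aromatic carbon can also raise the number above that of the methoxy compound, with a 3.0-fold higher number from compound 1 to compound 4 (0.48 log units; beyond the scatter) in this assay, which neither methyl nor butyl had done. Butyl and tert-butyl do not read alike at this place, the exchange giving a 3.0-fold higher number from compound 3 to compound 4 (0.48 log units; beyond the scatter), and the span across the alkyl groups widens to a 13-fold higher number from compound 2 to compound 4 (1.10 log units; beyond the scatter), the largest gap among the four compounds. Nothing in the data shown gives a reason for these differences.

The compounds shown leave open where ethyl or isopropyl would fall relative to the methyl of compound 2 and the tert-butyl of compound 4. They also leave open how an amine, a carboxylic acid or a chlorine atom on this aromatic carbon would read.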